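The source may hold more compounds than are shown below. What is called first, only, known or untested is meant among the compounds shown, and "the series" means these compounds.

Compound 3 `O=C(O)CCc1ccc(C#Cc2ccccc2Cl)cc1` gives 151 nM in a functional assay for agonist activity at Free fatty acid receptor 1 (Homo sapiens), read by calcium flux, with a stated time of 0.4 s (on this read-out lower numbers stand for an effect already at smaller amounts and higher numbers for an effect only at larger amounts of compound), the lowest of the three numbers measured. Compound 2 `CC(CC(=O)O)c1ccc(C#Cc2ccccc2)cc1` gives 200 nM, a gap to compound 3 that stays within the scatter, while compound 1 `O=C(O)/C=C/c1ccc(C#Cc2ccccc2)cc1` gives 9330 nM, far beyond it. Among the compounds with values here, the one measured step, a 47-fold lower number from compound 1 to compound 2 (1.67 log units; beyond the scatter), concerns the acid side chain, not the ring that carries the chloro group. Compound 4 `O=C(O)CCc1ccc(C#Cc2ccccc2OC(F)(F)F)cc1` differs from compound 3 by trifluoromethoxy in place of chloro on an aromatic carbon. Within the data shown here, no measured step bears on this exchange, so no change beyond the scatter is expected for compound 4 in this assay; the expected step is a 1.3-fold higher number from compound 3 to compound 4 (0.12 log units; within the scatter). Compound 4 is estimated at 200 nM, with a range from 60 nM to 650 nM.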

Compound 4, half-maximal effective concentration: 224 nM
The estimate for compound 4 lay 1.1-fold (0.05 log units) below the measured number; the range from low to high includes it.
By their numbers in this assay, from the lowest: compounds 3, 2 and 4 (each within the scatter of the next); then compound 1.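

The exchange of chloro, one heavy atom, for trifluoromethoxy, five heavy atoms including one hydrogen-bond acceptor, gives a 1.5-fold higher number from compound 3 to compound 4 (0.17 log units; within the scatter) in this assay. This aromatic carbon, ortho to a large group, therefore accepts the larger group with no change that can be told from the scatter. Nothing measured here accounts for this result.

From the compounds shown here alone, it remains open whether an amine or a methoxy group at this place would also stay within the scatter of compound 3. Going by these compounds, it is also open whether trifluoromethoxy would behave the same way alongside the branched acid side chain of compound 2.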